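From 2-Fluorophenyl to 3,4,5-Trimethoxyphenyl on a Shared Core

The compounds below may be only part of what the source reports. "The series", "measured", "known", "first", "only" and "open" are said of these compounds alone.

Compound 1 `O=C(OCc1ccccc1)N1CCN(C(=S)SCc2cn(Cc3ccc(Cl)cc3)nn2)CC1`: in a functional assay on ECa-109 cells (Homo sapiens) for inhibition, read by MTT assay, with a stated time of 72 h (on this read-out lower numbers stand for stronger inhibition and higher numbers for weaker inhibition), compound 1 gives > 128000 nM, which is a limit of the assay and not a number.
Compound 2 `Cc1ccc(Cn2cc(CSC(=S)N3CCN(C(=O)OCc4ccccc4)CC3)nn2)cc1`: compound 2 gives 32600 nM.
Compound 3 `O=C(OCc1ccccc1)N1CCN(C(=S)SCc2cn(Cc3ccccc3F)nn2)CC1`: compound 3 gives 27000 nM.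

Compound 3 holds the lowest of the two numbers, but its neighbour compound 2 sits close to it, as the step of a 1.2-fold lower number from compound 2 to compound 3 (0.08 log units; within the scatter) shows. The remaining value is only a limit (the limit of > 128000 nM in this assay, at which 1 of the 3 values shown sits). The two steps that carry weight are an at least 3.9-fold lower number from compound 1 to compound 2 (0.59 log units; beyond the scatter) and an at least 4.7-fold lower number from compound 1 to compound 3 (0.67 log units; beyond the scatter); both lower the number when the chloro-bearing group is exchanged, yet each is only a lower bound because it starts from a limit.

Compound 4 `COc1cc(Cn2cc(CSC(=S)N3CCN(C(=O)OCc4ccccc4)CC3)nn2)cc(OC)c1OC` differs from compound 3 in one place: 3,4,5-trimethoxyphenyl in place of 2-fluorophenyl on a saturated chain carbon bound to an aromatic nitrogen. Among the measured compounds shown here, no measured step changes the group on this chain carbon in a comparable way, so the measured pairs bear on it only loosely; they show that swapping one small substituted phenyl for another leaves the number roughly where it is. Compound 4 is therefore expected near 25000 nM, with a range from 8000 nM to 100000 nM. This estimate means an expected step of a 1.1-fold lower number from compound 3 to compound 4 (0.03 log units; within the scatter), not beyond the scatter.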

Compound 4, half-maximal inhibitory concentration: > 128000 nM
Compound 4 was reported as a limit; the forecaster's own chance of this, stated with the estimate: 15%; middle value at least 5.1-fold (0.70 log units) away from the limit.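

Placing 3,4,5-trimethoxyphenyl on the saturated chain carbon bound to an aromatic nitrogen gives an at least 4.7-fold higher number from compound 3 to compound 4 (0.67 log units; beyond the scatter), and the same exchange starting from 4-methylphenyl gives an at least 3.9-fold higher number from compound 2 to compound 4 (0.59 log units; beyond the scatter). In this assay, compound 4 gives > 128000 nM, which is a limit of the assay and not a number, and the step between compound 1 and compound 4 cannot be read. The closeness of compound 2 and compound 3 therefore does not extend to every substituted phenyl, and the 4-chlorophenyl of compound 1 is no longer the only group at this position that reaches the limit: the limit of > 128000 nM in this assay, at which 2 of the 4 values shown sit.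

The compounds shown cannot tell whether the three methoxy groups are needed together, which a phenyl carrying a single methoxy group would help to test. Going by these compounds, how a cyclohexyl group or a phenyl carrying an amine would behave at this position also remains open.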